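This account rests on a few compounds, and the source may have more. Where it says the series, first, only, none or still open, it means among the compounds named here.

Measured so far in a functional assay on HT-29 cells (Homo sapiens) for cytotoxicity, read by MTT assay, with a stated time of 72 h; on this read-out higher numbers stand for weaker inhibition and lower numbers for stronger inhibition 
- compound 1 `NCCCNc1c(C(=O)NCc2ccc(F)cc2)nc(Br)c2cccnc12` | "not determined" (no result reported) 
- compound 2 `N[C@H]1CC[C@H](Nc2c(C(=O)NCc3ccc(F)cc3)nc(Br)c3cccnc23)CC1` | < 1000 nM 

Compound 1 stands on no single number, and no result is reported for it. The only reference is the limit of < 1000 nM in this assay, at which 1 of the 2 values shown sits, and it belongs to compound 2, as a limit and not a number.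

Compound 3 `NCCCCCCNc1c(C(=O)NCc2ccc(F)cc2)nc(Br)c2cccnc12` is still unmeasured. The change 3-aminopropyl in place of amino on a saturated chain carbon, three bonds along the chain from a nitrogen on an aromatic ring puts 3-aminopropyl in place of amino on a saturated chain carbon, three bonds along the chain from a nitrogen on an aromatic ring. Going by the values given here, compound 1 offers no number to step from, and no measured step exists. The expectation in this assay is therefore no step beyond the usual scatter in either direction, taken against the limit of compound 2.

Compound 3 is estimated at 500 nM with an expected range of 100 nM to 2000 nM on this read-out.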

Compound 3, half-maximal inhibitory concentration: 5000 nM
For compound 3 the middle estimate is 10-fold (1.00 log units) below the measured one; measured number above the stated range.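

This position does not treat all amine-bearing groups alike: in this assay, 6-aminohexyl in place of 4-aminocyclohexyl on a nitrogen on an aromatic ring gives an at least 5.0-fold higher number from compound 2 to compound 3 (0.69 log units; beyond the scatter). The value of compound 2 is < 1000 nM, a limit and not a number. The size of the step is therefore a minimum, and the true gap may be larger: the limit of < 1000 nM in this assay, at which 1 of the 3 values shown sits.

As far as these compounds go, compound 1 has no reported result, so steps through it cannot be read, and the effect of chain length alone remains unknown, as does whether the ring of compound 2 or the length of the chain in compound 3 accounts for the step. Also open, from the compounds shown here alone, is how a 4-aminobutyl chain, or a hydroxyl in place of the amine of the chain, would read in this assay.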